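Anilino-purine-type series: pyrrolidine nitrogen capping, compound 2 to compound 4

A few compounds are considered here, and "the series" means these few. Any claim that something is new, unique, unknown or untested is made for them only; others in the source may bear on it.

Measured compounds:
- compound 1 `CN1CCN(c2ccc(Nc3ncc4nc(Nc5ccc(F)cc5)n([C@H]5CCCN(C(=O)CO)C5)c4n3)cc2)CC1`: 750 nM in a functional assay on NCI-H1975 cells (Homo sapiens) for antiproliferative activity, read by MTT assay, with a stated time of 72 h; on this read-out lower numbers stand for stronger inhibition and higher numbers for weaker inhibition
- compound 2 `CN1CCN(c2ccc(Nc3ncc4nc(Nc5ccccc5)n([C@@H]5CCNC5)c4n3)cc2)CC1`: "not determined" (no result reported) in this assay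
- compound 3 `CN1CCN(c2ccc(Nc3ncc4nc(Nc5ccc(F)cc5)n([C@H]5CCNC5)c4n3)cc2)CC1`: "not determined" (no result reported) in this assay

Within the data shown here, compound 2 stands without a number, its entry in this assay reading "not determined" (no result reported); the same holds for compound 3, whose entry reads "not determined" (no result reported), so the only number is that of compound 1, which in this assay gives 750 nM. Compound 4 `CN1CCN(c2ccc(Nc3ncc4nc(Nc5ccccc5)n([C@H]5CCN(S(=O)(=O)C6CC6)C5)c4n3)cc2)CC1` is not yet measured. Its change from compound 2 is 1-(cyclopropylsulfonyl)pyrrolidin-3-yl in place of pyrrolidin-3-yl on an aromatic nitrogen. Among the measured compounds shown here, no step between two measured compounds exists here, so nothing shows how capping of the pyrrolidine nitrogen moves the read-out, and no direction of the step from compound 2 to compound 4 can be stated beyond the scatter. The expectation for compound 4 rests only on compound 1, which carries a different capping group and a fluorine on the anilino ring while sharing the remaining core; its value gives the working anchor. Compound 4 is therefore estimated at 400 nM, with a range of 80 nM to 2000 nM.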

Compound 4, half-maximal inhibitory concentration: 240 nM
Compound 4: the middle estimate sits 1.7-fold (0.22 log units) above what was measured; low and high end bracket the measured number.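

In this assay, among these compounds, compound 4 gives 240 nM while compound 2 has no single number, so no step between compound 2 and compound 4 can be read. No evidence bears on this result. The compounds shown leave open how capping the pyrrolidine nitrogen moves the read-out.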